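A few compounds are considered here, and "the series" means these few. Any claim that something is new, unique, unknown or untested is made for them only; others in the source may bear on it.

Among the compounds with values here, the two compounds measured so far share one core and differ only in the aromatic group on the ring amine nitrogen. Compound 1, `Cn1c(=O)cnn(CCCCN2CCN(c3cccc(O)c3)CC2)c1=O`, carries a 3-hydroxyphenyl group. In an assay for displacement of a labelled ligand from Adrenergic receptor alpha-1 (Homo sapiens) (on this read-out higher numbers stand for weaker inhibition and lower numbers for stronger inhibition), compound 1 gives only a limit, > 10000 nM. Compound 2, `Cn1c(=O)cnn(CCCCN2CCN(c3cccc(F)n3)CC2)c1=O`, carries a 6-fluoropyridin-2-yl group instead. In this assay compound 2 likewise gives only a limit, > 10000 nM. The step that the two limits leave unreadable from compound 1 to compound 2 therefore cannot be read, because of the limit of > 10000 nM in this assay, at which 2 of the 2 values shown sit.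

Compound 3, `Cn1c(=O)cnn(CCCCN2CCN(c3cccc(Br)n3)CC2)c1=O`, is not yet measured; it changes compound 2 by bromo in place of fluoro on an aromatic carbon. Within the data shown here, the only measured step, from compound 1 to compound 2, bears on compound 3 solely in that both of its ends sit at the limit, so no step of readable size is available. Compound 3 is therefore expected to remain near the limit as well. For compound 3 the estimated step is a step that the limit leaves unreadable from compound 2 to compound 3, a change expected to stay within the usual scatter. The estimate for compound 3 is 15000 nM, within a range from 4000 nM to 60000 nM.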

Compound 3, inhibition constant: > 10000 nM
Compound 3: no number, only a limit; the forecaster's own chance of this, stated with the estimate: 75%; the middle value does not contradict the limit.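

Compound 3 also gives only a limit in this assay, so the steps among compound 1, compound 2 and compound 3 cannot be read, because all of them rest on one limit: (the limit of > 10000 nM in this assay, at which 3 of the 3 values shown sit). The compounds shown leave open how large these steps really are, and whether any aromatic group on the ring amine nitrogen of the shared core gives a measurable value in this assay.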